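This account rests on a few compounds, and the source may have more. Where it says the series, first, only, none or still open, it means among the compounds named here.

The measured compounds:
compound 1, `COC(=O)c1c(Nc2ccccc2)sc(C(=O)c2ccc(C)cc2)c1C`, gives 2.08%
compound 2, `COC(=O)c1c(Nc2ccc(C)cc2)sc(C(=O)c2ccc(C)cc2)c1C`, gives "not active" (no number reported)
compound 3, `COC(=O)c1c(Nc2ccc(F)cc2)sc(C(=O)c2ccc(C)cc2)c1C`, gives "not active" (no number reported)

Of the compounds shown here, three built on one shared core have been tested in a functional assay, with a stated time of 150 min, tested at 5 ug/mL; a lower number here means a weaker effect, a higher number a stronger effect of the compound at the concentration tested. Compound 1 gives 2.08% in this assay, a small effect at the concentration tested. Compound 2 is recorded in this assay as "not active" (no number reported), with no number attached. Compound 3 is likewise recorded in this assay as "not active" (no number reported); no single number stands for it, and it shares this standing with compound 2, so compound 3 cannot be placed above or below either neighbour on the numbers shown. All three sit at the weak end of what this read-out can report.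

The step to compound 4, `COC(=O)c1c(Nc2ccc(Cl)cc2)sc(C(=O)c2ccc(C)cc2)c1C`, is chloro in place of fluoro on an aromatic carbon. Within the data shown here, no measured pair shows this same change, so there is no comparison to lean on. Given the absent effect of compound 3 at "not active" (no number reported) and the small number for compound 1 at 2.08%, no step beyond the scatter is expected in this assay in either direction. Compound 4 is therefore expected to give 2% in this assay, within a range from 0% to 8%.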

Compound 4, a percentage reported as activity, at one concentration (the size of the read-out at that concentration, not a potency): "not active" (no number reported)
The entry for compound 4 holds no number, and the estimate cannot be compared.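

In this assay, among these compounds, compound 4 is recorded as "not active" (no number reported) and compound 3 likewise carries no number, so no step between them can be read. The compounds shown leave open whether the change from 4-fluorophenyl to 4-chlorophenyl has any effect on the shared core. Nothing shown offers an explanation for these entries.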